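The source may report more compounds than this note shows. Statements on the series, on what has been measured and on what is new or still open speak of the compounds shown alone.

Compound 1 `Cc1ccc(NC(=O)COc2nc3ccccc3nc2C)cc1` reaches only the limit of a functional assay on cells (Homo sapiens) for inhibition, read by MTT assay, with a stated time of 24 h; a higher number here means a weaker inhibitor, a lower number a stronger inhibitor: compound 1 gives > 100000 nM. Compound 2 `Cc1nc2ccccc2nc1OCC(=O)Nc1ccc(Cl)cc1` likewise stops at the limit, giving > 100000 nM. Among the compounds with values here, the step that the two limits leave unreadable from compound 1 to compound 2 cannot be read because of the limit of > 100000 nM in this assay, at which 2 of the 2 values shown sit, so no measured step carries information. Compound 3 `Cc1ccc(NC(=O)COc2nc3ccccc3nc2/C=C\c2ccncc2)cc1` differs from compound 1 by 2-(pyridin-4-yl)ethenyl in place of methyl on an aromatic carbon. Within the data shown here, no measured step bears on this change, so the estimate is open in size and direction, with a sizeable chance that the limit is reached again. Compound 3 is expected to give 40000 nM in this assay, within 4000 nM to 200000 nM. Among the measured compounds shown here, the expected step of an at least 2.5-fold lower number from compound 1 to compound 3 (0.39 log units; beyond the scatter) rests on no measured step.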

Compound 3, half-maximal inhibitory concentration: > 100000 nM
Compound 3 ended at the assay's limit (the forecaster's own chance of this, stated with the estimate: 50%); middle value at least 2.5-fold (0.39 log units) from the limit.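

No step from compound 1 to compound 3 can be read in this assay, because both compounds stop at the same limit: the limit of > 100000 nM in this assay, at which 3 of the 3 values shown sit.

The compounds shown leave open whether any change on the shared core moves the number in this assay.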